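The source may hold more compounds than are shown below. What is called first, only, known or untested is meant among the compounds shown, and "the series" means these compounds.

Measured compounds and their values:
Compound 1, `C=C1C[C@]23C[C@@]1(O)CC[C@H]2c1ccc(OS(=O)(=O)c2ccc(C)cc2)c(C)c1[C@@H]3Cn1cc(-c2ccc(Br)cc2)nn1`: > 20000 nM in a functional assay on HL-60 cells (Homo sapiens) for cytotoxicity, read by MTT assay, with a stated time of 4 days; a higher number here means a weaker inhibitor, a lower number a stronger inhibitor
Compound 2, `Cc1c(O)ccc2c1[C@H](Cn1cc(-c3ccccc3)nn1)[C@@]13CC(=O)[C@@](C)(CC[C@@H]21)C3`: > 20000 nM in this assay

In this assay compound 1 gives only a limit, > 20000 nM, and no number is known for it. Compound 2 likewise gives only a limit in this assay, > 20000 nM. Among the measured compounds shown here, the whole of the evidence is therefore (the limit of > 20000 nM in this assay, at which 2 of the 2 values shown sit), and no step between two measured compounds can be drawn from it.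

Compound 3, `C=C1C[C@]23C[C@@]1(O)CC[C@H]2c1ccc(OS(=O)(=O)c2ccc(C)cc2)c(C)c1[C@@H]3Cn1cc(-c2ccc(F)cc2)nn1`, is the untested partner of compound 1. The change from compound 1 to compound 3 is fluoro in place of bromo on an aromatic carbon; the rest of the molecule, including the shared core and the sulfonate on the aromatic ring, is kept. Since compound 1 shows no measurable inhibition, the writer expects the step that the limit leaves unreadable from compound 1 to compound 3 to be none beyond the scatter, with compound 3 most likely also returning a limit. Compound 3 is thus estimated at 25000 nM in this assay, within a range from 5000 nM to 100000 nM. That expectation rests on compound 1 giving only a limit, > 20000 nM.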

Compound 3, half-maximal inhibitory concentration: > 20000 nM
Compound 3 gave a limit, no number; the forecaster's own chance of this, stated with the estimate: 85%; the middle value does not contradict the limit.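

Compound 3, like compound 1, gives only a limit in this assay, so no new step can be read between compound 1 and compound 3. The compounds shown leave open how these two actually compare, and which change to the shared core or its groups, if any, would give a measurable value in this assay.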